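From Nitro to Bromo on the Outer Aromatic Ring

This account rests on a few compounds, and the source may have more. Where it says the series, first, only, none or still open, it means among the compounds named here.

Of the compounds shown here, two have been measured so far, and they share one core. Compound 1 `CCc1nc2ccccc2c(=O)n1NC(=O)Nc1ccc([N+](=O)[O-])cc1` and compound 2 `O=C(Nc1ccc([N+](=O)[O-])cc1)Nn1c(-c2ccccc2)nc2ccccc2c1=O` differ in one place: phenyl in place of ethyl on an aromatic carbon. In a functional assay on the whole organism (strain albino) with Mus musculus as the target, at a dose of 100 mg/kg by the intraperitoneal route (on this read-out lower numbers stand for less inhibition and higher numbers for more inhibition at the one dose given (going by the name of the read-out)), compound 1 gives 41%, and compound 2 gives 42%. The step of a number 1 percentage points higher from compound 1 to compound 2 (within the scatter) is within the scatter, so the two read-outs cannot be told apart. Compound 1 stands at the lower of the two numbers shown, its only neighbour being compound 2, but the gap is within the scatter and no order between them can be claimed.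

Compound 3 `CCc1nc2ccccc2c(=O)n1NC(=O)Nc1ccc(Br)cc1` has not yet been measured. It differs from compound 1 by bromo in place of nitro on an aromatic carbon. Within the data shown here, no measured pair changes the group at this position, so no step bears directly on this change; the one step known touched a different part of the molecule and stayed within the scatter. With nothing pointing in either direction, the expected step of no change at the digits printed from compound 1 to compound 3 (within the scatter) is none beyond the scatter. Compound 3 is therefore estimated at 41% in this assay, within a range from 25% to 57%.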

Compound 3, a percentage reported as inhibition, in the whole organism at one dose (the size of the read-out at that dose, not a potency): 54%
The estimate for compound 3 lay 13 percentage points below the measured number; the measured number falls inside the stated range.
By their numbers in this assay, from the lowest: compounds 1 and 2 (each within the scatter of the next); then compound 3.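

In this assay the swap of nitro for bromo, on an aromatic carbon para to a large group, gives a number 13 percentage points higher from compound 1 to compound 3 (beyond the scatter) and so shows that this read-out responds to the group held at this place. The only earlier step, a number 1 percentage points higher from compound 1 to compound 2 (within the scatter) for phenyl in place of ethyl, lay at a different part of the molecule and could not be told apart from the scatter, so this is the first change shown to shift the number clearly. The rise stands as an observation on this one pair, and no measurement here explains it.

On these data alone, whether the rise belongs to bromo in particular, or would also appear with another replacement for nitro at the same place, such as chloro, methyl, methoxy or an amine, stays open. Also open, as far as these compounds go, is whether bromo in place of nitro would give a similar step on compound 2, which carries phenyl instead of ethyl, since a single pair cannot show that a change carries over to a neighbouring structure.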